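A few compounds are considered here, and "the series" means these few. Any claim that something is new, unique, unknown or untested is made for them only; others in the source may bear on it.

Measured compounds, with their results in an assay on COS-7 cells for inhibition of patatin-like phospholipase domain-containing protein 2 (Mus musculus); a higher number here means a weaker inhibitor, a lower number a stronger inhibitor:

compound 1 `CCOC(=O)c1cccc(-c2ccc(OCC)cc2)c1`, compound 1 gives 50000 nM
compound 2 `CCOC(=O)c1cccc(-c2ccc(OCC)c([N+](=O)[O-])c2)c1`, compound 2 gives 200000 nM
compound 3 `CCOc1ccc(-c2cccc(S(=O)(=O)N(C)C)c2)cc1`, compound 3 gives 110000 nM

Compound 3 stands second highest of these three numbers. Going by the values given here, the gap between compound 3 and compound 2 lies within the scatter; the step of a 2.2-fold higher number from compound 1 to compound 3 (0.34 log units; beyond the scatter) is beyond it, so compound 1 is the only compound set apart from compound 3.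

Compound 4 `CCOc1ccc(-c2cccc(C)c2)cc1` is not yet measured. It differs from compound 3 by methyl in place of dimethylsulfamoyl on an aromatic carbon.

Among the compounds with values here, two measured steps touch this part of the series. The step of a 2.2-fold higher number from compound 1 to compound 3 (0.34 log units; beyond the scatter) concerns the same position of the shared core, but exchanges one group for another, neither of them methyl. The step of a 4.0-fold higher number from compound 1 to compound 2 (0.60 log units; beyond the scatter) sits elsewhere in the shared core. Both steps are modest, and all three numbers lie in a narrow, weak band. Within the data shown here, no measured step replaces a group at this position with methyl, so the direction is open; a step of the same modest size, or none beyond the scatter, is expected in this assay. For compound 4 the estimate is 80000 nM, with a range from 30000 nM to 250000 nM. That estimate means a step of a 1.4-fold lower number from compound 3 to compound 4 (0.14 log units; within the scatter).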

Compound 4, half-maximal inhibitory concentration: 70000 nM
Beside the measured number, compound 4's estimate is 1.1-fold (0.06 log units) above it; low and high end bracket the measured number.
By their numbers in this assay, from the lowest: compounds 1, 4, 3 and 2 (each within the scatter of the next, the first and the last beyond it).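

In this assay, methyl in place of dimethylsulfamoyl gives a 1.6-fold lower number from compound 3 to compound 4 (0.20 log units; within the scatter), and methyl in place of ethoxycarbonyl gives a 1.4-fold higher number from compound 1 to compound 4 (0.15 log units; within the scatter), so compound 4 is not separated from either compound. Dimethylsulfamoyl, with 6 heavy atoms and 2 hydrogen-bond acceptors, gives way here to methyl, with 1 heavy atom and no acceptor, and the number remains in the same weak band; at this position, the group exchanges shown so far do not open a large gap. No measurement available here accounts for this result.

On these data alone, whether an amine, a carboxylic acid or a longer chain at this position would leave the number in this band remains open. Also open, as far as these compounds go, is whether nitro in place of hydrogen would give a similar step on compound 4 as on compound 1.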